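Hydroxy- and methoxyphenyl triazoles on a bicyclic lactam core

The compounds below may be only part of what the source reports. "The series", "measured", "known", "first", "only" and "open" are said of these compounds alone.

Measured so far in a functional assay on HepG2 cells (Homo sapiens) for inhibition, read by MTT assay, with a stated time of 24 h; a lower number here means a stronger inhibitor, a higher number a weaker inhibitor:
compound 1 `CC1(C)[C@H]2CC[C@]1(C)N(Cc1cn(-c3ccccc3O)nn1)C(=O)C2` gives 120 nM
compound 2 `COc1ccccc1-n1cc(CN2C(=O)C[C@@H]3CC[C@@]2(C)C3(C)C)nn1` gives 110 nM
compound 3 `Cc1ccc(-n2cc(CN3C(=O)C[C@@H]4CC[C@@]3(C)C4(C)C)nn2)cc1` gives 480 nM

Compound 2 carries the lowest number of the three, but compound 1 sits within the scatter of it, so neither can be set above the other: a 1.1-fold lower number from compound 1 to compound 2 (0.04 log units; within the scatter). Compound 3 stands apart, with a 4.0-fold higher number from compound 1 to compound 3 (0.60 log units; beyond the scatter) and a 4.4-fold higher number from compound 2 to compound 3 (0.64 log units; beyond the scatter).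

Compound 4 `CC1(C)[C@H]2CC[C@]1(C)N(Cc1cn(-c3ccc(O)cc3)nn1)C(=O)C2` is not yet measured. Relative to compound 2 the change is 4-hydroxyphenyl in place of 2-methoxyphenyl on an aromatic nitrogen.

Within the data shown here, two measured steps bear on this. Moving the substituent pattern on the phenyl from the 2-methoxyphenyl of compound 2 to the 4-methylphenyl of compound 3 gave a modest rise, a 4.4-fold higher number from compound 2 to compound 3 (0.64 log units; beyond the scatter), while exchanging hydroxyl for methoxy on that phenyl, from compound 1 to compound 2, stayed within the scatter. Among the measured compounds shown here, no compound carries a 4-hydroxyphenyl, so the step is read only by analogy with compound 3. For the measured compounds named here, because of a 1.1-fold lower number from compound 1 to compound 2 (0.04 log units; within the scatter) showing the hydroxyl itself to be neutral, the rise expected in this assay is modest and somewhat smaller than the one seen for compound 3.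

For compound 4 the expected value in this assay is 250 nM, with a range of 110 nM to 600 nM, which means an expected step of a 2.3-fold higher number from compound 2 to compound 4 (0.36 log units; beyond the scatter).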

Compound 4, half-maximal inhibitory concentration: 80 nM
The estimate for compound 4 lay 3.1-fold (0.49 log units) above the measured number, and the stated range ends above it.
By their numbers in this assay, from the lowest: compounds 4, 2 and 1 (each within the scatter of the next); then compound 3.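

In this assay the 4-hydroxyphenyl on the aromatic nitrogen cannot be told apart from the 2-methoxyphenyl, with a 1.4-fold lower number from compound 2 to compound 4 (0.14 log units; within the scatter), or from the 2-hydroxyphenyl, with a 1.5-fold lower number from compound 1 to compound 4 (0.18 log units; within the scatter), so among these compounds a group in the 4-hydroxyphenyl pattern keeps the level of the other two oxygen-bearing phenyls. The high number of compound 3 therefore does not go with every 4-substituted phenyl: hydroxy in place of methyl on that aromatic carbon gives a 6.0-fold lower number from compound 3 to compound 4 (0.78 log units; beyond the scatter), and only the 4-methylphenyl stands apart. No measurement shown explains this difference.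

The compounds shown leave open whether a 4-methoxyphenyl would read like compound 4 or like compound 3. They also leave open how an amine or a carboxylic acid on that phenyl would read in this assay.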